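The compounds below may be only part of what the source reports. "The series", "measured", "known", "first", "only" and "open" are said of these compounds alone.

Measured compounds:

Compound 1, `COCCC1CN(c2ccccc2)NC1=O`, gives 480 nM; 10300 nM; 350 nM (3 entries) in an assay on isolated protein for inhibition of Polyunsaturated fatty acid 5-lipoxygenase (Rattus norvegicus); a higher number here means a weaker inhibitor, a lower number a stronger inhibitor.
Compound 2, `CCOCCC1CN(c2ccccc2)NC1=O`, gives 150 nM in this assay.

Compound 1 has repeat entries, and the several entries of compound 1 in this assay, 480 nM; 10300 nM; 350 nM (3 entries) shows that these spread far more widely than ordinary repetition would, so its position is loosely defined. Compound 2 stands on a single number, 150 nM, with one further entry that returned no number at all; on the values shown it sits at the lower end, though its gap to compound 1 cannot be called anything firmer given that spread.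

The account now moves from compound 2 to compound 3, `O=C1NN(c2ccccc2)CC1Cc1cccs1`. The change is thiophen-2-yl in place of ethoxymethyl on a saturated chain carbon bound to a saturated ring carbon. For the measured compounds named here, no measured pair tracks this change, so no step size is given to lean on. Compound 3 is expected to land close to compound 2, with the step from compound 2 to compound 3, a 1.7-fold higher number from compound 2 to compound 3 (0.22 log units; within the scatter), estimated as small and not clearly beyond the scatter in either direction. Compound 3 is therefore estimated at 250 nM, within a range from 60 nM to 1000 nM.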

Compound 3, half-maximal inhibitory concentration: 140 nM
Beside the measured number, compound 3's estimate is 1.8-fold (0.25 log units) above it; measured number inside the range.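

In this assay, putting thiophen-2-yl in place of ethoxymethyl on a saturated chain carbon bound to a saturated ring carbon gives a 1.1-fold lower number from compound 2 to compound 3 (0.03 log units; within the scatter), so the two compounds cannot be told apart. The earlier compounds shown here carried only open chains at this place, whereas here a group with one five-membered aromatic ring takes the place of a group with no ring, and the number stays within the scatter; on this single pair, the position keeps its level in this assay across that exchange. Compound 1 offers no firm third point for judging the position, since its entries spread too widely to fix its level: the several entries of compound 1 in this assay, 480 nM; 10300 nM; 350 nM (3 entries)

Going by these compounds, whether the position would keep this level with a group of a different kind, such as an amine, a carboxylic acid or a longer chain, remains open, as does whether a plain phenyl group would match thiophen-2-yl. A single step also leaves open whether the same exchange would stay this small on another core.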